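The compounds below may be only part of what the source reports. "The series", "measured", "known", "first", "only" and "open" are said of these compounds alone.

Measured compounds in the series:

compound 1, `CN(C)C(=S)N/N=C/c1ccc2cccnc2n1`, 630 nM
compound 2, `NC(=S)N/N=C/c1ccc2cccnc2n1`, a limit of the assay, > 100000 nM
compound 3, `CN(C)C(=S)N/N=C/c1cnc2ccccc2n1`, 170 nM

Values are from a functional assay on SGC-7901 cells (Homo sapiens) for antiproliferative activity, read by sulforhodamine B assay, with a stated time of 72 h; on this read-out higher numbers stand for weaker inhibition and lower numbers for stronger inhibition. Compound 1 and compound 2 differ in one place: amino in place of dimethylamino on a thiocarbonyl carbon. On this change the read-out moves by an at least 150-fold higher number from compound 1 to compound 2 (2.20 log units; beyond the scatter). For the measured compounds named here, the value of compound 2 is not a number but a limit of this assay; it is the one value that sits there, (the limit of > 100000 nM in this assay, at which 1 of the 3 values shown sits). Compound 3 is built from the same atoms as compound 1, joined differently; how the two cores differ is not broken down here. Against compound 1, compound 3 gives the lower of the two numbers, beyond the scatter.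

Compound 4, `NC(=S)N/N=C/c1cnc2ccccc2n1`, is not yet measured. It stands to compound 3 as compound 2 stands to compound 1: amino in place of dimethylamino on a thiocarbonyl carbon. The place of the change is the same in both pairs. In this assay the step is expected to be a 350-fold higher number from compound 3 to compound 4 (2.55 log units; beyond the scatter), resting on the measured step of an at least 150-fold higher number from compound 1 to compound 2 (2.20 log units; beyond the scatter). For compound 4 the estimate is 60000 nM, expected within 8000 nM to 300000 nM, with a fair chance that only a limit is returned.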

Compound 4, half-maximal inhibitory concentration: > 100000 nM
Compound 4 ended at the assay's limit (the forecaster's own chance of this, stated with the estimate: 55%); at least 1.6-fold (0.22 log units) between middle value and limit.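

In this assay, amino in place of dimethylamino on a thiocarbonyl carbon weakens the read-out on the second core as it did on the first, with an at least 580-fold higher number from compound 3 to compound 4 (2.76 log units; beyond the scatter). Compound 4 gives > 100000 nM, which is a limit of the assay and not a number, and it is not alone there: the limit of > 100000 nM in this assay, at which 2 of the 4 values shown sit. The direction of the change therefore carries over between these two cores, but its size does not allow a comparison, and two cores are too few to call it a general rule: the same change on two cores in this assay, an at least 150-fold higher number (2.20 log units; beyond the scatter) from compound 1 to compound 2 and an at least 580-fold higher number (2.76 log units; beyond the scatter) from compound 3 to compound 4; the limit leaves it open whether they differ.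

The compounds shown carry only dimethylamino and amino at this place, which leaves open where methylamino, diethylamino or a morpholine group would fall in this assay. Also open, on these data alone, is whether the change behaves alike on a core beyond these two, for instance one carrying a methoxy group or a chlorine atom.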